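Swapping ethoxy for chloro on a fused bicyclic core

This account rests on a few compounds, and the source may have more. Where it says the series, first, only, none or still open, it means among the compounds named here.

Of the compounds shown here, two have been measured in an ADME assay on a cell-free system (plasma, Mus musculus) for protein binding, using equilibrium dialysis, tested at 10 uM. Compound 1 `NC(=O)c1c(F)ccc(OCc2nc3cc(-c4ccccc4)ccc3s2)c1F` carries a phenyl group on its fused ring system, and in this assay compound 1 gives 99.2%. Compound 2 `CCOc1ccc2sc(COc3ccc(F)c(C(N)=O)c3F)nc2c1` carries an ethoxy group at the same position, and in this assay compound 2 gives 96.4%. For the measured compounds named here, the single step between them, a 4.5-fold higher unbound fraction from compound 1 to compound 2 (0.65 log units; beyond the scatter), is the only comparison available, and it places compound 2 at the higher of the two unbound fractions measured so far.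

Compound 3 `NC(=O)c1c(F)ccc(OCc2nc3cc(Cl)ccc3s2)c1F` is the next member of the series. Its difference from compound 2 is chloro in place of ethoxy on an aromatic carbon.

Going by the values given here, the one measured step bears on this change only loosely: it shows that exchanging the group at this position can move the unbound fraction by a modest amount. Chloro is a single heavy atom, smaller than both phenyl and ethoxy, so a large move is not anticipated. For compound 3 the expected outcome is a 1.4-fold lower unbound fraction from compound 2 to compound 3 (0.16 log units; within the scatter), that is, a shift toward the bound side of compound 2 but short of compound 1. The estimate for compound 3 is 97.5%, within a range from 95.5% to 98.8%.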

Compound 3, plasma protein binding: 96.4%
Estimate against measurement, compound 3: 1.4-fold (0.16 log units) (unbound fraction) below, within the range that was stated.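

Ethoxy and chloro cannot be told apart at this position in this assay: the measurement shows no change at the digits printed from compound 2 to compound 3 (within the scatter), even though ethoxy has 3 heavy atoms and chloro has 1. Phenyl is the group that stands apart among these three, since replacing it with chloro gives a 4.5-fold higher unbound fraction from compound 1 to compound 3 (0.65 log units; beyond the scatter), a step of the same size as the earlier one to ethoxy, a 4.5-fold higher unbound fraction from compound 1 to compound 2 (0.65 log units; beyond the scatter). Among these compounds, then, the unbound fraction separates the phenyl compound from the other two, while the difference in heavy atoms between ethoxy and chloro leaves no mark on the read-out, and no outside measurement is available to explain either finding.

For the compounds shown here, with only three groups compared, it remains open whether the level shared by compound 2 and compound 3 is typical of small groups at this position or a coincidence of these two. An amine, a carboxylic acid or a longer chain such as butoxy at the same aromatic carbon would test whether the unbound fraction can move beyond that level, and in which direction.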